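This account rests on a few compounds, and the source may have more. Where it says the series, first, only, none or still open, it means among the compounds named here.

Compound 1 `CCCCNC(=O)[C@H]1OC(n2cnc3c(N)ncnc32)[C@H](O)[C@@H]1O` carries a butyl group on the amide nitrogen of the shared core, and in an assay on cell membranes for binding affinity to 2-oxoglutarate receptor 1 (Rattus norvegicus), read by radioligand binding (on this read-out higher numbers stand for weaker inhibition and lower numbers for stronger inhibition), compound 1 gives 17 nM. Two companions stand beside it. Among the measured compounds shown here, compound 2 `NCCCCCCCCNC(=O)[C@H]1OC(n2cnc3c(N)ncnc32)[C@H](O)[C@@H]1O` gives 29 nM in this assay, and the single step of a 1.7-fold higher number from compound 1 to compound 2 (0.23 log units; within the scatter) stays within the scatter. For the measured compounds named here, compound 3 `Nc1ncnc2c1ncn2[C@@H]1O[C@H](C(=O)NC2CCCCC2)[C@@H](O)[C@H]1O`, with a cyclohexyl group on the same nitrogen, gives 18 nM; no single-point step links it to compound 1, but its number and that of compound 1 sit within the scatter of one another. Compound 1 thus shows a number that none of the other two separates from by more than the scatter.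

The step to compound 4 `Nc1ncnc2c1ncn2C1O[C@H](C(=O)NC2CCCCCCC2)[C@@H](O)[C@H]1O` is cyclooctyl in place of butyl on an amide-type nitrogen. The nearest guide is the pair of compound 1 and compound 3, whose numbers show that a six-membered ring in place of butyl changed almost nothing; the step from compound 1 to compound 2 shows that a much longer chain also stayed within the scatter. On that basis compound 4 is expected to lie close to compound 1, with the step of a 1.3-fold higher number from compound 1 to compound 4 (0.11 log units; within the scatter) estimated to remain within the scatter. Compound 4 is therefore estimated at 22 nM, in a range from 8 nM to 60 nM.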

Compound 4, inhibition constant: 23 nM
Compound 4: the middle estimate sits 1.0-fold (0.02 log units) below what was measured, and the stated range covers the measured number.
By their numbers in this assay, from the lowest: compounds 1, 3, 4 and 2 (each within the scatter of the next).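

The step of a 1.4-fold higher number from compound 1 to compound 4 (0.13 log units; within the scatter) in this assay shows that this amide-type nitrogen can carry an eight-membered ring of carbon only, with 8 heavy atoms where butyl has 4, and the number stays within the scatter of that of the butyl compound. The step of a 1.3-fold lower number from compound 2 to compound 4 (0.10 log units; within the scatter) adds that cyclooctyl and 8-aminooctyl cannot be told apart on this read-out, so neither the ring nor the amine of the chain appears here as a difference beyond the scatter. No measured evidence accompanies this result to explain it.

All the groups shown on this nitrogen are saturated, and the only one with a polar atom is 8-aminooctyl, so it remains open whether a phenyl ring, a carboxylic acid or a hydroxyl group at this place would move the number beyond the scatter. As far as these compounds go, it also remains open whether a methyl group in place of the amide hydrogen, a ring larger than cyclooctyl or a chain longer than 8-aminooctyl would keep the number within the scatter of these four compounds.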